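Putting a diethylamino group back on compound 3

The compounds below may be only part of what the source reports. "The series", "measured", "known", "first", "only" and "open" are said of these compounds alone.

In a functional assay on HL-60 cells (Homo sapiens) for antiproliferative activity, read by MTT assay, with a stated time of 48 h (a lower number here means a stronger inhibitor, a higher number a weaker inhibitor), compound 3 `N#Cc1nc2c(-c3nc4ccccc4[nH]3)c(N)n(CCCO)c2nc1C#N` gives > 50000 nM, which is a limit of the assay and not a number. Compound 2 `CCCCn1c(N)c(-c2nc3ccccc3[nH]2)c2nc(C#N)c(C#N)nc21` gives > 50000 nM, also a limit. Only compound 1 `CCN(CC)CCn1c(N)c(-c2nc3ccccc3[nH]2)c2nc(C#N)c(C#N)nc21` gives an actual number, 1880 nM.

The next compound, compound 4 `CCN(CC)CCCCn1c(N)c(-c2nc3ccccc3[nH]2)c2nc(C#N)c(C#N)nc21`, has not been measured yet. In it, (diethylamino)methyl takes the place of hydroxy on a saturated chain carbon, three bonds along the chain from an aromatic nitrogen ((diethylamino)methyl in place of hydroxy on a saturated chain carbon, three bonds along the chain from an aromatic nitrogen). Read one bond further out, 3-hydroxypropyl becomes 4-(diethylamino)butyl.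

For the measured compounds named here, two measured steps bear on this change. Both took the diethylamino group away, and both were large: an at least 26-fold higher number from compound 1 to compound 2 (1.42 log units; beyond the scatter) and an at least 26-fold higher number from compound 1 to compound 3 (1.42 log units; beyond the scatter). The change here brings that group back, so a large step toward a lower number, meaning a stronger inhibitor, is expected: an at least 20-fold lower number from compound 3 to compound 4 (1.30 log units; beyond the scatter). Going by the values given here, no measured pair tests chain length with the diethylamino group kept, so the value of compound 1, 1880 nM, serves only as a rough anchor. The estimate for compound 4 is 2500 nM, with an expected range from 600 nM to 12000 nM.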

Compound 4, half-maximal inhibitory concentration: 460 nM
Estimate against measurement, compound 4: 5.4-fold (0.74 log units) above; measured number below the stated range.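

Compound 4 shows that a diethylamino group at the end of the chain also matters on the longer chain in this assay, with an at least 100-fold lower number from compound 3 to compound 4 (2.03 log units; beyond the scatter) and an at least 100-fold lower number from compound 2 to compound 4 (2.03 log units; beyond the scatter). For the compounds shown here, it also gives the first comparison of chain length with that group kept, which is a 4.1-fold lower number from compound 1 to compound 4 (0.61 log units; beyond the scatter), a modest step but one beyond the scatter. The two large steps start from limits and not from numbers, and the step between compound 2 and compound 3 cannot be read at all: the limit of > 50000 nM in this assay, at which 2 of the 4 values shown sit.

Going by these compounds, whether a chain longer than the 4-(diethylamino)butyl of compound 4 would lower the number further remains open. So does whether another amine at the chain end, such as dimethylamino or piperidine, would serve as well as diethylamino.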